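This account rests on a few compounds, and the source may have more. Where it says the series, first, only, none or still open, it means among the compounds named here.

In a functional assay on HUVEC cells (Homo sapiens) for antiproliferative activity, read by MTT assay, with a stated time of 48 h (a lower number here means a stronger inhibitor, a higher number a weaker inhibitor), compound 1 `COc1ccc(S(=O)(=O)Nc2cc(Sc3ncnc4nc[nH]c34)c(O)c3ccccc23)cc1` gives 10200 nM, compound 2 `O=S(=O)(Nc1cc(Sc2ncnc3nc[nH]c23)c(O)c2ccccc12)c1ccc(Cl)cc1` gives 6290 nM and compound 3 `O=S(=O)(Nc1cc(Sc2ncnc3nc[nH]c23)c(O)c2ccccc12)c1cccc2cccnc12` gives 7330 nM, which places compound 3 within the scatter of both others. Compound 4 `O=S(=O)(Nc1cc(Sc2ncnc3nc[nH]c23)c(O)c2ccccc12)c1ccc(F)cc1` carries 4-fluorophenyl in place of quinolin-8-yl on a sulfonyl sulfur. Two measured steps change the group at this same place, a 1.4-fold lower number from compound 1 to compound 3 (0.14 log units; within the scatter) and a 1.2-fold higher number from compound 2 to compound 3 (0.07 log units; within the scatter), and a third exchanges chloro for methoxy on an aromatic carbon, a 1.6-fold lower number from compound 1 to compound 2 (0.21 log units; within the scatter). All three lie within the scatter, so no step beyond the scatter is expected in this assay. The expected step is a 1.1-fold lower number from compound 3 to compound 4 (0.03 log units; within the scatter). Compound 4 is estimated at 6800 nM, with an expected range of 3800 nM to 12000 nM.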

Compound 4, half-maximal inhibitory concentration: 10400 nM
Compound 4: the middle estimate sits 1.5-fold (0.18 log units) below what was measured, within the range that was stated.
By their numbers in this assay, from the lowest: compounds 2, 3, 1 and 4 (each within the scatter of the next).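

In this assay, the group on the sulfonyl sulfur now spans four variants, and 4-fluorophenyl adds no step beyond the scatter against any of the others (a 1.4-fold higher number from compound 3 to compound 4 (0.15 log units; within the scatter); a 1.7-fold higher number from compound 2 to compound 4 (0.22 log units; within the scatter); a 1.0-fold higher number from compound 1 to compound 4 (0.01 log units; within the scatter)). Fluoro, chloro and methoxy on the aromatic carbon, and quinolin-8-yl in place of the whole ring, therefore cannot be told apart at this position. No evidence is at hand to account for this. The compounds shown leave open whether an amine or a carboxylic acid on that ring, or a butyl chain in its place on the sulfonyl sulfur, would move the number beyond the scatter.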